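Hydrazone acid series: methoxy for hydroxy on the aryl ring

The source may hold more compounds than are shown below. What is called first, only, known or untested is meant among the compounds shown, and "the series" means these compounds.

Measured compounds in a functional assay on the whole organism for inhibition, with Rattus norvegicus as the target; a higher number here means that more compound is needed for the effect, a lower number that less compound is needed:
compound 1, `CC1CC/C(=N\Nc2cccc(Br)c2)c2ncc(C(=O)O)c(=O)n21`, gives 0.4 umol/kg
compound 2, `CC1CC/C(=N\Nc2ccc(Br)cc2)c2ncc(C(=O)O)c(=O)n21`, gives 0.8 umol/kg
compound 3, `CC1CC/C(=N\Nc2ccc(O)cc2)c2ncc(C(=O)O)c(=O)n21`, gives 1.7 umol/kg

Compound 3 carries the highest number of the three; the nearest is a 2.1-fold higher number from compound 2 to compound 3 (0.33 log units; beyond the scatter) and the furthest a 4.3-fold higher number from compound 1 to compound 3 (0.63 log units; beyond the scatter), both beyond the scatter. Compound 4, `COc1ccc(N/N=C2\CCC(C)n3c2ncc(C(=O)O)c3=O)cc1`, is the next compound in this assay. Compound 3 to compound 4: methyl in place of hydrogen on an oxygen on an aromatic ring. Going by the values given here, no measured step covers this change; the steps in hand vary the aryl substituent as a whole or swap bromo for hydroxy, so they give no direct read on capping the hydroxy with methyl. With nothing to point either way, the expected step of a 1.1-fold lower number from compound 3 to compound 4 (0.05 log units; within the scatter) is small, within the scatter. Compound 4 is estimated at 1.5 umol/kg, range 0.6 umol/kg to 4 umol/kg.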

Compound 4, dose for 50% inhibition: 0.8 umol/kg
Compound 4: middle estimate off by 1.9-fold (0.27 log units), on the high side, within the range that was stated.
By their numbers in this assay, from the lowest: compounds 1, 2 and 4 (each within the scatter of the next); then compound 3.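

Methyl in place of hydrogen on the oxygen lowers the number in this assay (a 2.1-fold lower number from compound 3 to compound 4 (0.33 log units; beyond the scatter)), so the free hydroxy of the 4-hydroxyphenyl group is not required for the effect in these compounds. Methoxy in place of bromo leaves the number unchanged (no change at the digits printed from compound 2 to compound 4 (within the scatter)), and the step from the 3-bromophenyl group also stays within the scatter (a 2.0-fold higher number from compound 1 to compound 4 (0.30 log units; within the scatter)), which leaves compound 3 alone at the high end. No supporting data bear on why capping the oxygen shifts the number.

As far as these compounds go, whether a longer chain on that oxygen, such as ethoxy, keeps the number at this level remains open. So does whether an amine in the same place on the aryl ring would read like hydroxy or like methoxy.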